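Unsaturated side chain in place of octyl on two related cores

A few compounds are considered here, and "the series" means these few. Any claim that something is new, unique, unknown or untested is made for them only; others in the source may bear on it.

Measured so far in a functional assay on MDA-MB-231 cells (Homo sapiens) for antiproliferative activity, read by MTT assay; a higher number here means a weaker inhibitor, a lower number a stronger inhibitor:
compound 1 `CCCCC/C=C\C/C=C\CCCCCCCC1(O)CC(=O)c2c(O)cc(OCOC)cc2O1` gives 16100 nM
compound 2 `CCCCCCCCCCCCCCCc1cc(=O)c2c(O)c(C)c(O)c(C)c2o1` gives > 87000 nM
compound 3 `CCCCCCCCCCCCCCCC1(O)CC(=O)c2c(O)cc(OCOC)cc2O1` gives > 87000 nM

The value of compound 2 is a limit of the assay, not a number. The value of compound 3 is likewise only a limit. For the measured compounds named here, the one counted change is deca-1,4-dien-1-yl in place of octyl on a saturated chain carbon, seven bonds along the chain from a saturated ring carbon, and it gives an at least 5.4-fold lower number from compound 3 to compound 1 (0.73 log units; beyond the scatter). The size of that step can be read only as a minimum because of the limit of > 87000 nM in this assay, at which 2 of the 3 values shown sit.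

Compound 4 `CCCCC/C=C\C/C=C\CCCCCCCc1cc(=O)c2c(O)c(C)c(O)c(C)c2o1` is not yet measured. It differs from compound 2 by deca-1,4-dien-1-yl in place of octyl on a saturated chain carbon, seven bonds along the chain from an aromatic carbon. This is the same kind of change as from compound 3 to compound 1, but the surroundings differ: in compound 1 the chain sits seven bonds from a saturated ring carbon, in compound 4 seven bonds from an aromatic carbon. The difference between the core of compound 2 and the core of compound 3 is not broken down here.

The expectation for compound 4 rests on the step from compound 3 to compound 1, an at least 5.4-fold lower number from compound 3 to compound 1 (0.73 log units; beyond the scatter), carried over to the core of compound 2; since compound 2 sits at a limit, the expected step of an at least 2.4-fold lower number from compound 2 to compound 4 (0.39 log units; beyond the scatter) is itself uncertain in size. In this assay compound 4 is estimated at 35000 nM, expected between 10000 nM and 87000 nM.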

Compound 4, half-maximal inhibitory concentration: 16100 nM
Beside the measured number, compound 4's estimate is 2.2-fold (0.34 log units) above it; the measured number falls inside the stated range.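

In this assay, deca-1,4-dien-1-yl in place of octyl on the core of compound 2 gives an at least 5.4-fold lower number from compound 2 to compound 4 (0.73 log units; beyond the scatter), so the change that lowered the number on the core of compound 3 also lowers it on this second core, and the two steps can be set side by side: the same change on two cores in this assay, an at least 5.4-fold lower number (0.73 log units; beyond the scatter) from compound 3 to compound 1 and an at least 5.4-fold lower number (0.73 log units; beyond the scatter) from compound 2 to compound 4; the limit leaves it open whether they differ

Compound 2 gives > 87000 nM, which is a limit of the assay and not a number.

The result therefore shows the direction of the change on both cores and a minimum size for each step, but not the true size of either step, nor whether one core responds more than the other: the limit of > 87000 nM in this assay, at which 2 of the 4 values shown sit.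

Still open, from the compounds shown here alone, is whether the steps follow the double bonds or the added chain length; decyl at the same place would separate the two. Also open, going by these compounds, is whether a chain ending in a carboxylic acid or an amine would behave alike on both cores.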